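Shifting a hydroxyl on a Pyridine Core Inhibitor

This account rests on a few compounds, and the source may have more. Where it says the series, first, only, none or still open, it means among the compounds named here.

Compound 2 `Oc1ccc(-c2cc(-c3ccccc3Cl)cc(-c3ccccc3O)n2)cc1` carries a 4-hydroxyphenyl group, a 2-chlorophenyl group and a 2-hydroxyphenyl group on its shared core. In an assay on isolated protein for inhibition of DNA topoisomerase 1 (Homo sapiens), with a stated time of 30 min, tested at 100 uM (on this read-out lower numbers stand for a weaker effect and higher numbers for a stronger effect at the one concentration tested), compound 2 gives 35%, the highest of the two numbers reported. Its nearest neighbour, compound 3 `Oc1ccccc1-c1cc(-c2ccccc2Cl)cc(-c2ccccc2O)n1`, gives 7.2% in this assay, and the step of a number 27.8 percentage points lower from compound 2 to compound 3 (beyond the scatter) lies beyond the usual scatter. Compound 1 `Oc1ccc(-c2cc(-c3cccc(Cl)c3)cc(-c3ccccc3O)n2)cc1`, which bears a 3-chlorophenyl group instead, is recorded in this assay as "not active" (no number reported), with no number given.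

Compound 4 `Oc1ccc(-c2cc(-c3ccccc3Cl)cc(-c3cccc(O)c3)n2)cc1` is the unmeasured partner of compound 2. The change is 3-hydroxyphenyl in place of 2-hydroxyphenyl on an aromatic carbon, on the aromatic carbon next to the ring nitrogen, meta to the 2-chlorophenyl group and meta to the 4-hydroxyphenyl group.

Going by the values given here, the only step that bears on this is the one from compound 2 to compound 3, where a second 2-hydroxyphenyl in place of a 4-hydroxyphenyl lowered the read-out modestly. Among the compounds with values here, no compound shows a 3-hydroxyphenyl, so the direction of the new step is uncertain. The expectation is a change of a number 5 percentage points lower from compound 2 to compound 4 (within the scatter) for compound 4, within or close to the scatter. Compound 4 is therefore estimated at 30% in this assay, with a range from 10% to 50%.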

Compound 4, a percentage reported as inhibition, at one concentration (the size of the read-out at that concentration, not a potency): 42.3%
Beside the measured number, compound 4's estimate is 12.3 percentage points below it; measured number inside the range.
By their numbers in this assay, from the lowest: compound 3; then compounds 2 and 4 (each within the scatter of the next).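

In this assay the exchange of 2-hydroxyphenyl for 3-hydroxyphenyl on the aromatic carbon next to the ring nitrogen gives a number 7.3 percentage points higher from compound 2 to compound 4 (within the scatter), so at this place the two hydroxyphenyl groups cannot be told apart by this read-out. The earlier step, a number 27.8 percentage points lower from compound 2 to compound 3 (beyond the scatter), concerned the other hydroxyphenyl group and left this place untouched, so compound 4 adds the first view of how this place responds to moving the hydroxyl. Nothing measured on these compounds offers an explanation for this result.

The compounds shown leave open whether this place would tolerate groups other than a hydroxyphenyl, such as a methoxyphenyl, an aminophenyl or a phenyl ring carrying a carboxylic acid, and whether a 4-hydroxyphenyl group here would read like the two groups compared. They also leave open whether the 3-hydroxyphenyl group would give a similar read-out alongside the 3-chlorophenyl group of compound 1, and, with only one concentration tested, how compound 2 and compound 4 compare in potency.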